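One Stereocentre Turned: From Compound 2 to Compound 3

The compounds below may be only part of what the source reports. "The series", "measured", "known", "first", "only" and "open" are said of these compounds alone.

Of the compounds shown here, two sharing a core have been measured in an assay on SK-OV-3 cells for inhibition of eIF-2-alpha kinase GCN2 (Homo sapiens); a lower number here means a stronger inhibitor, a higher number a weaker inhibitor. Compound 1, `Brc1nn(-c2ccc3ncccc3c2)c2nc(Nc3cnn(C4CCNCC4)c3)ncc12`, gives 610 nM. Compound 2, `COCCNC(=O)[C@H]1CC[C@@H](Nc2ncc3c(Br)nn(-c4ccc5ncccc5c4)c3n2)C1`, gives 156 nM in this assay, the lowest of the two numbers; its nearest neighbour, compound 1, stands higher by a gap that is beyond the usual scatter.

Compound 3, `COCCNC(=O)[C@@H]1CC[C@@H](Nc2ncc3c(Br)nn(-c4ccc5ncccc5c4)c3n2)C1`, has not been measured. Compared with compound 2, (the two compounds have the same atoms and bonds and differ only in configuration as drawn: 1 of 2 stereo elements differ; a stereocentre at a saturated ring carbon is drawn S in compound 2 and R in compound 3). Among the measured compounds shown here, no step between measured compounds matches this kind of change, so there is nothing measured that fixes its direction or size. A change of configuration at a stereocentre can leave the number nearly unchanged or move it in either direction, sometimes well beyond the scatter. Since compound 2 already holds the lower number of the two, a modest weakening is taken as the expected outcome, and the expected step from compound 2 to compound 3 in this assay is a 2.6-fold higher number from compound 2 to compound 3 (0.41 log units; beyond the scatter). Compound 3 is estimated at 400 nM, with a range from 80 nM to 2500 nM.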

Compound 3, half-maximal inhibitory concentration: 20 nM
Compound 3: the middle estimate sits 20-fold (1.30 log units) above what was measured, and the stated range ends above it.
By their numbers in this assay, from the lowest: compound 3; then compound 2; then compound 1.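

Turning the stereocentre at the saturated ring carbon from S to R gives a 7.8-fold lower number from compound 2 to compound 3 (0.89 log units; beyond the scatter) in this assay, and this is the first step in the series that can be read as a single change. The step can be tied to that one stereocentre, because no other difference separates the pair: the fact that compounds 2 and 3 differ only in the configuration as drawn. At this ring carbon, then, the same atoms and bonds do not guarantee the same number, and the spatial arrangement alone moves the result by more than the usual scatter.

On these data alone, the second stereo element stays the same in both compounds, so the effect of turning it, alone or together with the first, remains open. As far as these compounds go, it is also open whether the same preference for R would hold if a carboxylic acid or a simple amine stood in place of the methoxyethyl amide, since both compounds in this step carry that same amide.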